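Aniline ring substitution and mouse microsomal clearance

The source may report more compounds than this note shows. Statements on the series, on what has been measured and on what is new or still open speak of the compounds shown alone.

Measured compounds:
compound 1, `CN1C[C@H](C(=O)Nc2ccccc2)[C@@H](c2ccc(/C=C/C(=O)Nc3ccccc3N)cc2)C1`, 67 mL/min/kg
compound 2, `CN1C[C@H](C(=O)Nc2ccc(C3CC3)cc2)[C@@H](c2ccc(/C=C/C(=O)Nc3ccccc3N)cc2)C1`, 60 mL/min/kg
compound 3, `CN1C[C@H](C(=O)Nc2cccc(F)c2)[C@@H](c2ccc(/C=C/C(=O)Nc3ccccc3N)cc2)C1`, 56 mL/min/kg

In an in vitro ADME assay on microsomes from liver (Mus musculus) for pharmacokinetics, read by LC-MS, with a stated time of 10 min, tested at 1 uM (on this read-out lower numbers stand for slow clearance and higher numbers for fast clearance), compound 1 gives the highest of the three numbers, but its gaps to compound 2 and to compound 3 both fall within the scatter, so no ordering among the three is established. Compound 4 `CN1C[C@H](C(=O)Nc2ccc(F)c(Br)c2)[C@@H](c2ccc(/C=C/C(=O)Nc3ccccc3N)cc2)C1` is not yet measured; it differs from compound 1 in one place: 3-bromo-4-fluorophenyl in place of phenyl on an amide-type nitrogen. Two measured steps change the same ring: a 1.1-fold lower number from compound 1 to compound 2 (0.05 log units; within the scatter) and a 1.2-fold lower number from compound 1 to compound 3 (0.08 log units; within the scatter). The remaining step, a 1.1-fold lower number from compound 2 to compound 3 (0.03 log units; within the scatter), is also within the scatter. Nothing here indicates that substitution on this ring moves this assay beyond the scatter, so for compound 4 no step beyond the scatter is expected, a 1.2-fold lower number from compound 1 to compound 4 (0.08 log units; within the scatter). For compound 4 the estimated value is 56 mL/min/kg, with a range from 35 mL/min/kg to 90 mL/min/kg.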

Compound 4, clearance: 43 mL/min/kg
Estimate against measurement, compound 4: 1.3-fold (0.11 log units) above; the range from low to high includes it.
By their numbers in this assay, from the lowest: compounds 4, 3, 2 and 1 (each within the scatter of the next).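

In this assay, the 3-bromo-4-fluorophenyl group on the amide-type nitrogen stays within the scatter of all three earlier compounds (a 1.6-fold lower number from compound 1 to compound 4 (0.19 log units; within the scatter)) (a 1.4-fold lower number from compound 2 to compound 4 (0.14 log units; within the scatter)) (a 1.3-fold lower number from compound 3 to compound 4 (0.11 log units; within the scatter)). The position therefore tolerates a ring carrying both bromine and fluorine without a step beyond the scatter, which extends the earlier finding from singly substituted rings. Nothing available explains these numbers.

On these data alone, whether an amine or a carboxylic acid on this ring would move clearance beyond the scatter remains open. So does the outcome of a pyridine in place of the phenyl.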